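Adding a Methoxy Group to Compound 2

This account rests on a few compounds, and the source may have more. Where it says the series, first, only, none or still open, it means among the compounds named here.

Within the data shown here, in a functional assay, with a stated time of 60 min (a higher number here means a weaker inhibitor, a lower number a stronger inhibitor), compound 2 (`O=C(/C=C/c1ccc(O)cc1)OCCOc1no[n+]([O-])c1S(=O)(=O)c1ccccc1`) gives 6240000 nM, the higher of the two numbers so far, and compound 1 (`O=C(/C=C/c1ccc(O)c(O)c1)OCCOc1no[n+]([O-])c1S(=O)(=O)c1ccccc1`) gives 219000 nM. Compound 3 (`COc1cc(/C=C/C(=O)OCCOc2no[n+]([O-])c2S(=O)(=O)c2ccccc2)ccc1O`) has methoxy in place of hydrogen on an aromatic carbon, ortho to a hydroxy group: methoxy in place of hydrogen on an aromatic carbon. Among the measured compounds shown here, one measured step bears on that carbon, the large 28-fold higher number from compound 1 to compound 2 (1.45 log units; beyond the scatter), where hydrogen replaces hydroxy. Methoxy is a different group, so only part of that gap is expected to close, giving an expected 4.2-fold lower number from compound 2 to compound 3 (0.62 log units; beyond the scatter). For compound 3 the estimate is 1500000 nM, with an expected range of 300000 nM to 6000000 nM.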

Compound 3, half-maximal inhibitory concentration: 669000 nM
For compound 3 the middle estimate is 2.2-fold (0.35 log units) above the measured one; low and high end bracket the measured number.
By their numbers in this assay, from the lowest: compound 1; then compound 3; then compound 2.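

Among these compounds, putting methoxy on the carbon ortho to a hydroxy group gives a 9.3-fold lower number from compound 2 to compound 3 (0.97 log units; beyond the scatter) in this assay, so hydroxy is not the only group here that lowers the number. Methyl in place of the hydrogen on that oxygen gives a 3.1-fold higher number from compound 1 to compound 3 (0.48 log units; beyond the scatter), so the free hydroxy of compound 1 still outperforms methoxy at this position. No available evidence explains either step.

Still open, on these data alone, is whether an amine, a fluorine atom or a longer chain such as ethoxy on this carbon would also lower the number.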